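Carbamate-linked arylselenocyanates: removing the nitro group

This account rests on a few compounds, and the source may have more. Where it says the series, first, only, none or still open, it means among the compounds named here.

Series notes. The measured members share one selenocyanate-bearing core: compound 1 `CCCOC(=O)Nc1ccc([Se]C#N)cc1`, compound 2 `CCCCCCOC(=O)Nc1ccc([Se]C#N)cc1` and compound 3 `N#C[Se]c1ccc(NC(=O)OCc2ccc([N+](=O)[O-])cc2)cc1`. In a functional assay on CCRF-CEM cells (Homo sapiens) for cytotoxicity, read by MTT assay, with a stated time of 72 h (a lower number here means a stronger inhibitor of growth, a higher number a weaker inhibitor of growth), compound 1 gives 9300 nM, compound 2 gives 19700 nM and compound 3 gives 9300 nM. Compound 3 stands level with compound 1, the two together holding the lowest numbers of the set. Among the compounds with values here, the one measured step within the set is a 2.1-fold higher number from compound 1 to compound 2 (0.33 log units; beyond the scatter), so compound 2 lies furthest from compound 3. Compound 4 `N#C[Se]c1ccc(NC(=O)OCc2ccccc2)cc1` differs from compound 3 by hydrogen in place of nitro on an aromatic carbon. Within the data shown here, no measured step touches this kind of change; the only step in hand concerns a chain and does not bear on it. Nothing therefore argues for a shift beyond the scatter, and the step of no change at the digits printed from compound 3 to compound 4 (within the scatter) is expected to be small. Compound 4 is estimated at 9300 nM, with a range from 4000 nM to 21000 nM.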

Compound 4, concentration for 50% growth inhibition: 23200 nM
The estimate for compound 4 lay 2.5-fold (0.40 log units) below the measured number; measured number outside the range, above it.
By their numbers in this assay, from the lowest: compounds 1 and 3 (each within the scatter of the next); then compounds 2 and 4 (each within the scatter of the next).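

In this assay the aromatic carbon para to a large group proves responsive: hydrogen in place of nitro gives a 2.5-fold higher number from compound 3 to compound 4 (0.40 log units; beyond the scatter) and so is not a neutral exchange. Phenyl in place of ethyl gives a 2.5-fold higher number from compound 1 to compound 4 (0.40 log units; beyond the scatter) while phenyl in place of pentyl gives a 1.2-fold higher number from compound 2 to compound 4 (0.07 log units; within the scatter) and thus compound 4 falls with compound 2, apart from compound 1. No available data explain the step from nitro to hydrogen.

Open, on these data alone, is whether an amine or a methoxy group on this aromatic carbon would match compound 3 or compound 4.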